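Diastereomeric Epoxide Tested Against a Lung Cancer Cell Line

The source may report more compounds than this note shows. Statements on the series, on what has been measured and on what is new or still open speak of the compounds shown alone.

Compound 2 `C=CC(=C)[C@H](O)C[C@H]1C(=C)CC[C@@H]2[C@]1(C)CCC[C@]2(C)C(=O)O` stands at the limit of a functional assay on A549 cells (Homo sapiens) for cytotoxicity, read by MTT assay, with a stated time of 48 h; a higher number here means a weaker inhibitor, a lower number a stronger inhibitor: in this assay compound 2 gives > 40000 nM, which is a limit rather than a number. Compound 1 `C=C[C@@]1(C)O[C@H]1C[C@H]1C(=C)CC[C@@H]2[C@]1(C)CCC[C@]2(C)C(=O)O` carries the three-membered ring with 1 hetero atom instead of the open chain. In this assay compound 1 gives > 40000 nM, also a limit. Among the measured compounds shown here, the step that the two limits leave unreadable from compound 1 to compound 2 therefore cannot be read; it shows only that both values sit at the limit of > 40000 nM in this assay, at which 2 of the 2 values shown sit. Compound 3 `C=C[C@]1(C)O[C@H]1C[C@H]1C(=C)CC[C@@H]2[C@]1(C)CCC[C@]2(C)C(=O)O` differs from compound 2 by a group of 6 heavy atoms (5 carbon, 1 oxygen; one three-membered non-aromatic ring with 1 hetero atom) in place of a group of 6 heavy atoms (5 carbon, 1 oxygen; no ring), on a saturated chain carbon bound to a saturated ring carbon. Compound 3 thus closes the chain back into the same kind of ring that compound 1 bears, with a different configuration there. For the measured compounds named here, since compound 1 and compound 2 both sit at the limit of > 40000 nM in this assay, at which 2 of the 2 values shown sit, no measured step gives a direction or a size, and no change beyond the scatter is expected. Compound 3 is therefore expected to give 50000 nM, between 20000 nM and 200000 nM, most likely again as a limit. The expected step that the limit leaves unreadable from compound 2 to compound 3 is essentially none.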

Compound 3, half-maximal inhibitory concentration: > 40000 nM
Compound 3 ended at the assay's limit (the forecaster's own chance of this, stated with the estimate: 85%); the middle value is on the limit's open side.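

No step can be read among compound 1, compound 2 and compound 3 in this assay, since all three values are limits rather than numbers: (the limit of > 40000 nM in this assay, at which 3 of the 3 values shown sit). From the compounds shown here alone, whether the three-membered ring or its configuration changes cytotoxicity stays open, as does the true value of each compound.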